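The source may report more compounds than this note shows. Statements on the series, on what has been measured and on what is new or still open speak of the compounds shown alone.

Measured compounds in a functional assay on MGC-803 cells (Homo sapiens) for antiproliferative activity, read by CCK-8 assay, with a stated time of 72 h, tested at 8 uM; a higher number here means a stronger effect of the compound at the concentration tested, a lower number a weaker effect:
Compound 1, `Nc1ccccc1NC(=O)c1ccc(CSC(=S)N2CCc3ccccc32)cc1`: 87%
Compound 2, `Nc1ccccc1NC(=O)c1ccc(CSC(=S)N2CCc3cc(Cl)ccc32)cc1`: 82.2%
Compound 3, `CCN(Cc1ccncc1)C(=S)SCc1ccc(C(=O)Nc2ccccc2N)cc1`: 85.2%

All three numbers sit close together. Compound 3 stands second highest of the three; the two gaps that lead to it are a number 1.8 percentage points lower from compound 1 to compound 3 (within the scatter) and a number 3 percentage points higher from compound 2 to compound 3 (within the scatter), both within the scatter, so the three compounds cannot be told apart in this assay.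

Compound 4, `Nc1ccccc1NC(=O)c1ccc(CSC(=S)N2CCCC2)cc1`, is not yet measured. It differs from compound 3 at the thiocarbonyl carbon: pyrrolidin-1-yl in place of ethyl((pyridin-4-yl)methyl)amino on a thiocarbonyl carbon

Among the measured compounds shown here, the steps that bear on this change are the two that swap the group on the thiocarbonyl carbon, a number 1.8 percentage points lower from compound 1 to compound 3 (within the scatter) and a number 3 percentage points higher from compound 2 to compound 3 (within the scatter). Neither moved the number beyond the scatter, although the groups exchanged there differ widely in size and ring type. On that basis no step beyond the scatter is expected for a number 2.2 percentage points lower from compound 3 to compound 4 (within the scatter). For compound 4 in this assay the expected value is 83%, with a range of 70% to 92%.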

Compound 4, a percentage reported as inhibition, at one concentration (the size of the read-out at that concentration, not a potency): 83.4%
Beside the measured number, compound 4's estimate is 0.4 percentage points below it, and the stated range covers the measured number.
By their numbers in this assay, from the lowest: compounds 2, 4, 3 and 1 (each within the scatter of the next).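

In this assay, pyrrolidin-1-yl, with 5 heavy atoms and one five-membered non-aromatic ring, replaces ethyl((pyridin-4-yl)methyl)amino, with 10 heavy atoms and one six-membered aromatic ring, and the result is a number 1.8 percentage points lower from compound 3 to compound 4 (within the scatter). The comparisons with the two dihydroindolyl groups read the same way, a number 1.2 percentage points higher from compound 2 to compound 4 (within the scatter) and a number 3.6 percentage points lower from compound 1 to compound 4 (within the scatter), so a group on the thiocarbonyl carbon with no aromatic ring still cannot be told apart from the three groups that carry one. Nothing on hand accounts for this flat result.

From the compounds shown here alone, how a morpholin-4-yl group, a piperazin-1-yl group with its free amine, or a carboxylic acid-bearing chain would read at this position remains open. A read-out at one concentration gives no potency, so any separation among these compounds at lower concentrations also remains open.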